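A Methyl Replaces an Amino Group on a Shared Core

The source may report more compounds than this note shows. Statements on the series, on what has been measured and on what is new or still open speak of the compounds shown alone.

Compound 1 `Nc1nc(N)c2c(-c3ccsc3)cn([C@@H]3O[C@H](CO)[C@@H](O)[C@H]3O)c2n1`: > 20000 nM
Compound 2 `COc1nc(N)nc2c1c(-c1ccsc1)cn2[C@@H]1O[C@H](CO)[C@@H](O)[C@H]1O`: > 20000 nM
Compound 3 `CNc1ncnc2c1c(-c1cccs1)cn2[C@@H]1O[C@H](CO)[C@@H](O)[C@H]1O`: > 20000 nM

All three were tested in a functional assay on HCT-116 cells (Homo sapiens), read by MTT assay, with a stated time of 72 h; on this read-out higher numbers stand for weaker inhibition and lower numbers for stronger inhibition. In this assay compound 1 gives > 20000 nM, which is a limit of the assay rather than a number. Compound 2 likewise gives > 20000 nM, a limit. Compound 3 also gives > 20000 nM, again a limit. Compound 1 therefore stands only at a limit, with no number of its own. Going by the values given here, the one measured step is a step that the two limits leave unreadable from compound 1 to compound 2, so it carries no usable size.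

Compound 4 `Cc1nc(N)c2c(-c3ccsc3)cn([C@@H]3O[C@H](CO)[C@@H](O)[C@H]3O)c2n1` differs from compound 1 in one place: methyl in place of amino on an aromatic carbon. No readable step bears on this change, so no direction beyond the scatter can be inferred. Because (the limit of > 20000 nM in this assay, at which 3 of the 3 values shown sit), compound 4 is expected to show a step that the limit leaves unreadable from compound 1 to compound 4. The estimate for compound 4 is 30000 nM, with a range from 10000 nM to 100000 nM.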

Compound 4, half-maximal inhibitory concentration: > 20000 nM
Compound 4 was reported as a limit (the forecaster's own chance of this, stated with the estimate: 80%); the middle value is on the limit's open side.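

Compound 1 and compound 4 both stand only at a limit in this assay, so no step from compound 1 to compound 4 can be read: the limit of > 20000 nM in this assay, at which 4 of the 4 values shown sit.

The compounds shown leave open whether amino or methyl at this place makes any difference to inhibition.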